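Removing one methyl from the side chain of compound 3

The compounds below may be only part of what the source reports. "The series", "measured", "known", "first", "only" and "open" are said of these compounds alone.

Measured so far in a functional assay on HeLa cells (Homo sapiens) for cytotoxicity, read by MTT assay; a higher number here means a weaker inhibitor, a lower number a stronger inhibitor:
Compound 1 `CC(C)=CC[C@@H](OC[C@H](C)O)C1=CC(=O)c2c(O)ccc(O)c2C1=O` gives 40300 nM
Compound 2 `CC(C)=CC[C@@H](OC(=O)c1ccco1)C1=CC(=O)c2c(O)ccc(O)c2C1=O` gives 80300 nM
Compound 3 `CCCC(C)(O)CC(=O)O[C@H](CC=C(C)C)C1=CC(=O)c2c(O)ccc(O)c2C1=O` gives 72000 nM

All three compounds share one core and differ only in the group carried on an oxygen on a saturated carbon. Compound 3, at 72000 nM, cannot be told apart from the other two: the steps of a 1.1-fold lower number from compound 2 to compound 3 (0.05 log units; within the scatter) and a 1.8-fold higher number from compound 1 to compound 3 (0.25 log units; within the scatter) are both within the usual scatter.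

Compound 4 `CCC(C)(O)CC(=O)O[C@H](CC=C(C)C)C1=CC(=O)c2c(O)ccc(O)c2C1=O` makes a much smaller change, (hydrogen in place of methyl on a saturated chain carbon, three bonds along the chain from an oxygen on a saturated carbon). In words, this is hydrogen in place of methyl, which turns propyl into ethyl at the end of the chain.

Among the compounds with values here, the steps that bear on it are the two above. Even swapping the whole group, as in a 1.1-fold lower number from compound 2 to compound 3 (0.05 log units; within the scatter), gave no step beyond the scatter in this assay. So no real shift is expected here, and the direction stays open. The estimate is a step of a 1.0-fold lower number from compound 3 to compound 4 (0.01 log units; within the scatter), which is expected to stay within the scatter. Compound 4 is expected at about 70000 nM. Its estimated range runs from 40000 nM to 120000 nM.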

Compound 4, half-maximal inhibitory concentration: 25200 nM
For compound 4 the middle estimate is 2.8-fold (0.44 log units) above the measured one; measured number below the stated range.
By their numbers in this assay, from the lowest: compounds 4, 1, 3 and 2 (each within the scatter of the next, the first and the last beyond it).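

In this assay, shortening propyl to ethyl gives a 2.9-fold lower number from compound 3 to compound 4 (0.46 log units; beyond the scatter), so this site, on a saturated chain carbon, three bonds along the chain from an oxygen on a saturated carbon, can respond to the loss of one carbon, even though the earlier whole-group swaps stayed within the scatter. Placing 2-hydroxy-2-methylbutyl instead of furan-2-yl on the carbonyl carbon also gives a step beyond the scatter, a 3.2-fold lower number from compound 2 to compound 4 (0.50 log units; beyond the scatter), while a 1.6-fold lower number from compound 1 to compound 4 (0.20 log units; within the scatter) stays within it. Nothing available here explains why removing one methyl shifts the number.

Any trend with chain length rests on this one step, so it remains open whether a methyl in place of the ethyl or a butyl in place of the propyl would continue it. An amine or a carboxylic acid at the chain end would show whether length alone matters here.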